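A few compounds are considered here, and "the series" means these few. Any claim that something is new, unique, unknown or untested is made for them only; others in the source may bear on it.

In a functional assay on U-251 cells (Homo sapiens) for cytotoxicity (a higher number here means a weaker inhibitor of growth, a lower number a stronger inhibitor of growth), three compounds that share one core have been measured. Compound 1 (`COc1ccc(C2=C(c3ccc(SC)cc3)CC3CCCN3C2=O)cc1Br`) gives 800 nM, compound 2 (`CSc1ccc(C2=C(c3ccc(O)c(O)c3)C(=O)N3CCCC3C2)cc1`) gives 30000 nM, and compound 3 (`CSc1ccc(C2=C(c3ccc(Br)cc3)C(=O)N3CCCC3C2)cc1`) gives 7000 nM. Compound 3 therefore holds the middle of the three numbers, with a 4.3-fold lower number from compound 2 to compound 3 (0.63 log units; beyond the scatter) on one side and an 8.8-fold higher number from compound 1 to compound 3 (0.94 log units; beyond the scatter) on the other.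

The next compound, compound 4 (`CSc1ccc(C2=C(c3ccc(F)cc3)C(=O)N3CCCC3C2)cc1`), differs from compound 3 in a single place: fluoro in place of bromo on an aromatic carbon. The fluoro sits on an aromatic carbon, para to a large group. Among the measured compounds shown here, no measured step makes this exchange, so the evidence is indirect. All three steps change the same aryl group, and the largest is a 38-fold higher number from compound 1 to compound 2 (1.57 log units; beyond the scatter), so the numbers do respond to changes there. Each of those steps replaces a whole substituted phenyl pattern, however, whereas here only one atom is exchanged, which suggests a smaller move. The direction is uncertain, with a slight lean towards a higher number, resting on compound 2, which carries no bromo, and on a 4.3-fold lower number from compound 2 to compound 3 (0.63 log units; beyond the scatter). The expected change is a 1.4-fold higher number from compound 3 to compound 4 (0.15 log units; within the scatter), small to modest at most. For compound 4 the estimated value in this assay is 10000 nM, with an expected range from 4000 nM to 25000 nM.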

Compound 4, concentration for 50% growth inhibition: 90 nM
Beside the measured number, compound 4's estimate is 110-fold (2.05 log units) above it, and the stated range ends above it.
By their numbers in this assay, from the lowest: compound 4; then compound 1; then compound 3; then compound 2.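

In this assay, among the compounds shown here, the earlier steps each replaced a whole substituted phenyl pattern, and they left open how much a single atom on this ring could matter. The exchange of bromo for fluoro on an aromatic carbon, para to a large group, gives a 78-fold lower number from compound 3 to compound 4 (1.89 log units; beyond the scatter) and so shows that this one atom alone can shift the number strongly, with no other part of the molecule changed. The 4-fluorophenyl group also displaces the 3-bromo-4-methoxyphenyl group as the best of the aryl groups shown, with an 8.9-fold lower number from compound 1 to compound 4 (0.95 log units; beyond the scatter) and with a 330-fold lower number from compound 2 to compound 4 (2.52 log units; beyond the scatter) at the other end of the series, which makes compound 4 the strongest inhibitor of growth of the four.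

No measurement is at hand that accounts for the gap between the two halogens. As far as these compounds go, with only bromo and fluoro compared directly at this position, it remains open whether chloro, a nitrile or trifluoromethyl would sit near compound 4 or near compound 3, and whether the parent phenyl without any substituent would behave like either of them.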